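The source may report more compounds than this note shows. Statements on the series, on what has been measured and on what is new or still open speak of the compounds shown alone.

Values measured in a functional assay on MCF7 cells (Homo sapiens) for cytotoxicity, read by MTT assay, with a stated time of 96 h (on this read-out higher numbers stand for weaker inhibition and lower numbers for stronger inhibition), for three compounds:
- compound 1 (`COc1cc(C(=O)c2cn(-c3ccccc3)cc2-c2ccccc2[N+](=O)[O-])cc(OC)c1OC`) gives 49 nM
- compound 2 (`COc1cc(C(=O)c2cn(-c3ccc(C)cc3)cc2-c2ccccc2[N+](=O)[O-])cc(OC)c1OC`) gives 65 nM
- compound 3 (`COc1cc(C(=O)c2cn(-c3ccc(F)cc3)cc2-c2ccccc2F)cc(OC)c1OC`) gives 39 nM

Compound 3 stands level with the other two: its value lies within the scatter of both compound 1 and compound 2, so these numbers do not rank the three. The next compound, compound 4 (`COc1cc(C(=O)c2cn(-c3ccc(F)cc3)cc2-c2ccccc2[N+](=O)[O-])cc(OC)c1OC`), alters one group of compound 3, turning 2-fluorophenyl into 2-nitrophenyl (nitro in place of fluoro on an aromatic carbon). This is nitro in place of fluoro on an aromatic carbon, ortho to a large group.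

Among the compounds with values here, no measured pair makes this exchange directly. Within the data shown here, the only measured step is a 1.3-fold higher number from compound 1 to compound 2 (0.12 log units; within the scatter) for methyl in place of hydrogen on an aromatic carbon, so it bears on the question only indirectly. More useful is that compound 1 and compound 2 already carry the 2-nitrophenyl group, and their values (compound 1 at 49 nM and compound 2 at 65 nM) lie within the scatter of the value for compound 3 (39 nM). On that basis, no step beyond the scatter is expected in this assay for this exchange. The expected step is a 1.3-fold higher number from compound 3 to compound 4 (0.11 log units; within the scatter) and its direction remains uncertain. For compound 4 the estimated value is 50 nM with an expected range from 22 nM to 115 nM as the likely span.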

Compound 4, half-maximal inhibitory concentration: 38 nM
Beside the measured number, compound 4's estimate is 1.3-fold (0.12 log units) above it; the measured number falls inside the stated range.
By their numbers in this assay, from the lowest: compounds 4, 3, 1 and 2 (each within the scatter of the next).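

In this assay, within the data shown here, the exchange of fluoro for nitro on this aromatic carbon, ortho to a large group, now has a direct reading: a 1.0-fold lower number from compound 3 to compound 4 (0.01 log units; within the scatter) shows that the two groups cannot be told apart here, although the earlier compounds could suggest this only indirectly. With the 2-nitrophenyl group held fixed, the substituent elsewhere can also be read, as a 1.3-fold lower number from compound 1 to compound 4 (0.11 log units; within the scatter) gives fluoro in place of hydrogen and a 1.7-fold lower number from compound 2 to compound 4 (0.23 log units; within the scatter) gives fluoro in place of methyl, so hydrogen, methyl and fluoro at that place do not separate these compounds either. The data shown offer no measurement that would explain this flat picture.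

The compounds shown carry only fluoro or nitro on this aromatic carbon, so it remains open whether an amine, a carboxylic acid or a plain hydrogen there would stay within the scatter as well. Among these compounds, it is also open whether the 2-fluorophenyl and 2-nitrophenyl groups would remain level with a methyl or a hydrogen in place of the fluoro on the other aromatic ring, since compound 3 is the only 2-fluorophenyl compound here.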